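Shortening the Amine Arm on a Shared Sulfonamide Core

The source may hold more compounds than are shown below. What is called first, only, known or untested is meant among the compounds shown, and "the series" means these compounds.

Three measured compounds share one core and differ only in where and how an amine hangs from the aromatic ring. In an ADME assay on isolated protein for inhibition of carbonic anhydrase 4 (Homo sapiens), read by stopped-flow, with a stated time of 15 min (a lower number here means a stronger inhibitor, a higher number a weaker inhibitor), compound 1 `CN(C)c1cccc(S(=O)(=O)[N-][N+](=O)[O-])c1` gives 4500 nM, compound 2 `CN(C)c1ccccc1S(=O)(=O)[N-][N+](=O)[O-]` gives 32200 nM, and compound 3 `NCc1ccc(S(=O)(=O)[N-][N+](=O)[O-])cc1` gives 3100 nM. Compound 3 shows the lowest number of the three, though its gap to compound 1 lies within the scatter, so those two cannot be ranked; compound 2 sits clearly higher, beyond the scatter.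

Compound 4 `Nc1ccc(S(=O)(=O)[N-][N+](=O)[O-])cc1` has not been measured. It differs from compound 3 in a single place: amino in place of aminomethyl on an aromatic carbon. In plain terms, the carbon link between ring and amine is removed and the nitrogen sits directly on the ring. Going by the values given here, no measured pair shows this exact change, so the expectation rests on compound 3 alone. Compound 4 is expected to give about 2500 nM in this assay, somewhere between 800 nM and 8000 nM. The expected step is a 1.2-fold lower number from compound 3 to compound 4 (0.09 log units; within the scatter), which is not expected to go beyond the scatter in either direction.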

Compound 4, inhibition constant: 23600 nM
Compound 4: middle estimate off by 9.4-fold (0.97 log units), on the low side, outside the stated range (above it).
By their numbers in this assay, from the lowest: compounds 3 and 1 (each within the scatter of the next); then compounds 4 and 2 (each within the scatter of the next).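

In this assay, removing the single carbon link between ring and amine matters: amino in place of aminomethyl on an aromatic carbon gives a 7.6-fold higher number from compound 3 to compound 4 (0.88 log units; beyond the scatter), a step beyond the scatter. Going by these compounds alone, this is the first pair here that differs in one place, so it is the first direct sign that this position responds to a change in the link, and here the aminomethyl group carries the lower number. Nothing available explains why one carbon makes this difference.

As far as these compounds go, whether a longer chain such as aminoethyl on the same aromatic carbon would lower the number further remains open. Also open, from the compounds shown here alone, is whether hydroxymethyl, with oxygen in place of the amine nitrogen, would stay close to compound 3 or move towards compound 4.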